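One added methyl on compound 2

The source may report more compounds than this note shows. Statements on the series, on what has been measured and on what is new or still open speak of the compounds shown alone.

- compound 1 `Cc1cc2nc(-c3cn(-c4ccccc4)nc3-c3ccc(F)cc3)[nH]c2cc1C` gives > 50000 nM (a limit)
- compound 2 `COc1ccc(-c2nn(-c3ccccc3)cc2-c2nc3cc(C)ccc3[nH]2)cc1` gives 5070 nM

In a functional assay on A549 cells (Homo sapiens) for antiproliferative activity, read by MTT assay, with a stated time of 48 h (on this read-out lower numbers stand for stronger inhibition and higher numbers for weaker inhibition), compound 1 reaches only a limit, > 50000 nM. For the measured compounds named here, compound 2 gives 5070 nM, the only actual number so far, so it has no measured neighbour for comparison. Compound 3 `COc1ccc(-c2nn(-c3ccccc3)cc2-c2nc3cc(C)c(C)cc3[nH]2)cc1` differs from compound 2 by one change, a methyl in place of hydrogen on an aromatic carbon. Going by the values given here, no measured pair shows the effect of this change in this assay, so no shift beyond the usual scatter is expected, with only a slight lean towards weaker inhibition. The expected step is a 1.4-fold higher number from compound 2 to compound 3 (0.14 log units; within the scatter). For compound 3 the estimated value is 7000 nM, with an expected range of 2500 nM to 25000 nM.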

Compound 3, half-maximal inhibitory concentration: 5850 nM
Compound 3: middle estimate off by 1.2-fold (0.08 log units), on the high side; measured number inside the range.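

In this assay, methyl in place of hydrogen on this aromatic carbon, ortho to a methyl group, gives a 1.2-fold higher number from compound 2 to compound 3 (0.06 log units; within the scatter), so this position takes a second methyl with no shift beyond the scatter. With both methyls present, methoxy in place of fluoro on an aromatic carbon gives an at least 8.5-fold lower number from compound 1 to compound 3 (0.93 log units; beyond the scatter), a step that rests on a limit. Compound 1 stands at that limit and has no actual number: the limit of > 50000 nM in this assay, at which 1 of the 3 values shown sits. The compounds shown leave open how an amine, a carboxylic acid or a longer chain would behave on this aromatic carbon. Going by these compounds, the full size of the methoxy step also stays open.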